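The compounds below may be only part of what the source reports. "The series", "measured", "known", "first", "only" and "open" are said of these compounds alone.

Measured so far:
- compound 1 `Nc1ncc(-c2cc([C@H]3CCCO3)nc(N3C[C@@H]4C[C@H]3CO4)n2)nc1OC(F)F`: 202 nM
- compound 2 `Nc1ncc(-c2cc(N3CC4CC3C4)nc(N3C[C@@H]4C[C@H]3CO4)n2)nc1OC(F)F`: 35 nM

In an assay on Sf21 cells for inhibition of mitogen-activated protein kinase kinase kinase 13 (Homo sapiens), read by HTRF, with a stated time of 1.5 h (a higher number here means a weaker inhibitor, a lower number a stronger inhibitor), compound 1 gives 202 nM and stands highest of the two numbers; its nearest neighbour is compound 2, which lies a 5.8-fold lower number from compound 1 to compound 2 (0.76 log units; beyond the scatter). Compound 3 `Nc1ncc(-c2cc(C3CC3)nc(N3C[C@@H]4C[C@H]3CO4)n2)nc1OC(F)F` differs from compound 1 by cyclopropyl in place of oxolan-2-yl on an aromatic carbon. Among the measured compounds shown here, the only measured step, a 5.8-fold lower number from compound 1 to compound 2 (0.76 log units; beyond the scatter), concerns the same position but brings in a different group, so it bears on the new change only loosely and gives no direction for it. The step from compound 1 to compound 3 is therefore expected to stay small, a 1.1-fold lower number from compound 1 to compound 3 (0.05 log units; within the scatter), with wide uncertainty. Compound 3 is estimated at 180 nM, between 50 nM and 650 nM.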

Compound 3, half-maximal inhibitory concentration: 61 nM
Compound 3: the middle estimate sits 3.0-fold (0.47 log units) above what was measured; the range from low to high includes it.
By their numbers in this assay, from the lowest: compounds 2 and 3 (each within the scatter of the next); then compound 1.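

In this assay, cyclopropyl in place of oxolan-2-yl on this aromatic carbon gives a real gain (a 3.3-fold lower number from compound 1 to compound 3 (0.52 log units; beyond the scatter)), so the improvement at this position is not confined to the group carried by compound 2. The two replacements are not separated (a 1.7-fold higher number from compound 2 to compound 3 (0.24 log units; within the scatter)), although the group in compound 3 is the smaller of the two. No measurement bears on the reason for these steps. As far as these compounds go, whether the ring oxygen or the ring size sets compound 1 apart remains open. A cyclopentyl or dimethylamino group here would bear on that.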